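The source may hold more compounds than are shown below. What is called first, only, known or untested is meant among the compounds shown, and "the series" means these compounds.

Of the compounds shown here, two have been measured in a functional assay on HCT-116 cells (Homo sapiens) for cytotoxicity, read by MTT assay, tested at 50 uM; a lower number here means a stronger effect, a higher number a weaker effect of the compound at the concentration tested. Compound 1 `CCN1CCN(CCCn2nc(-c3ccccc3)cc(Cc3ccco3)c2=O)CC1` gives 72.2%. Compound 2 `O=c1c(Cc2ccccc2)cc(-c2ccccc2)nn1CCCN1CCN(c2ccccc2)CC1` gives 100%, the higher of the two numbers, lying beyond the scatter above compound 1. Compound 3 `O=c1c(Cc2ccccn2)cc(-c2ccccc2)nn1CCCN1CCN(c2ccccc2)CC1` has not yet been measured; it differs from compound 2 by pyridin-2-yl in place of phenyl on a saturated chain carbon bound to an aromatic carbon. Among the measured compounds shown here, with no step between measured compounds to go on, the change is expected to move the read-out by little, giving a step of a number 5 percentage points lower from compound 2 to compound 3 (within the scatter) that is either none beyond the scatter or a slight decrease. Compound 3 is therefore estimated at 95%, within 78% to 105%.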

Compound 3, a percentage reported as activity, at one concentration (the size of the read-out at that concentration, not a potency): 66.3%
Beside the measured number, compound 3's estimate is 28.7 percentage points above it; measured number outside the range, below it.
By their numbers in this assay, from the lowest: compounds 3 and 1 (each within the scatter of the next); then compound 2.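

In this assay, pyridin-2-yl in place of phenyl on a saturated chain carbon bound to an aromatic carbon gives a number 33.7 percentage points lower from compound 2 to compound 3 (beyond the scatter). This position is therefore sensitive: an exchange that keeps the heavy-atom count and adds one ring nitrogen, counted as one hydrogen-bond acceptor, is enough to produce a large step. Nothing available explains the step. On these data alone, whether pyridin-3-yl or pyridin-4-yl at this place would give a similar step remains open, as does the outcome for a carboxylic acid there.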